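Sulfonyl Substituent Variation in a Hydroxy-Trifluoromethyl Amide Series

The compounds below may be only part of what the source reports. "The series", "measured", "known", "first", "only" and "open" are said of these compounds alone.

Measured compounds:
compound 1 `Cc1ccccc1S(=O)(=O)c1ccc(NC(=O)C(C)(O)C(F)(F)F)cc1`: 5100 nM
compound 2 `CN(c1ccccc1)S(=O)(=O)c1ccc(NC(=O)C(C)(O)C(F)(F)F)cc1`: 2000 nM

The two measured compounds share the same core and differ only in the group attached to the sulfonyl sulfur. In a functional assay (Cavia porcellus) with sulfonylurea receptors; K-ATP channels (Homo sapiens) as the target (on this read-out higher numbers stand for weaker inhibition and lower numbers for stronger inhibition), compound 1 gives 5100 nM, and in this assay compound 2 gives 2000 nM. Within the data shown here, the change from compound 1 to compound 2 produced a 2.6-fold lower number from compound 1 to compound 2 (0.41 log units; beyond the scatter), so compound 2 has the lowest of the two numbers recorded here, with compound 1 as its only neighbour.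

Compound 3 `CC(O)(C(=O)Nc1ccc(S(=O)(=O)c2cnccn2)cc1)C(F)(F)F` has not yet been measured in this assay. It differs from compound 2 by pyrazin-2-yl in place of methyl(phenyl)amino on a sulfonyl sulfur. Among the measured compounds shown here, the only measured step, a 2.6-fold lower number from compound 1 to compound 2 (0.41 log units; beyond the scatter), bears on this position, but it exchanged one carbon-only aromatic ring for another aryl-type amino group rather than for a ring with two hetero atoms, so it is an indirect guide. For the measured compounds named here, no measured pair shows what an aromatic ring with hetero atoms does at this place.

Given that, compound 3 is expected to lie close to compound 2 in this assay, with a step of a 1.3-fold higher number from compound 2 to compound 3 (0.10 log units; within the scatter) that is estimated to stay within or only slightly beyond the scatter. The estimated value for compound 3 is 2500 nM, with an expected range from 800 nM to 8000 nM.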

Compound 3, half-maximal inhibitory concentration: 12000 nM
Estimate against measurement, compound 3: 4.8-fold (0.68 log units) below, and the stated range ends below it.
By their numbers in this assay, from the lowest: compound 2; then compound 1; then compound 3.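

In this assay this position proves far from indifferent to a ring with hetero atoms on the sulfonyl sulfur: pyrazin-2-yl in place of methyl(phenyl)amino gives a 6.0-fold higher number from compound 2 to compound 3 (0.78 log units; beyond the scatter) and is the largest step seen so far, while pyrazin-2-yl in place of 2-methylphenyl gives a 2.4-fold higher number from compound 1 to compound 3 (0.37 log units; beyond the scatter) and shows that the loss is not confined to the comparison with the amino-linked group. Among these compounds, the earlier pair showed only that moving between two groups with carbon-only aromatic rings shifted the number modestly, whereas the new compound puts the ring with hetero atoms at the weak end of the three, with compound 2 the strongest and compound 1 in the middle. Nothing available explains why the number rises with this change, so the finding stands as an observation only.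

The three compounds cannot say whether the rise follows from the two ring nitrogens together, from either one alone, or from the particular ring in which they sit. A pyridin-2-yl or plain phenyl group on the sulfonyl sulfur would address that question, and a dimethylamino group would show whether the amino link needs its phenyl ring at all.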